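Replacing phenyl with furan-2-yl: an expected growth inhibition

The compounds below may be only part of what the source reports. "The series", "measured", "known", "first", "only" and "open" are said of these compounds alone.

Measured so far:
compound 1 (`COc1ccc(/C=C/C(=O)/C=C/c2ccc(OCc3cn(CCCCOc4cc(=O)oc5ccccc45)nn3)c(OC)c2)cc1OC`) gives 53% 
compound 2 (`COc1cc(/C=C/C(=O)/C=C/c2cccc3ccccc23)ccc1OCc1cn(CCCCCOc2cc(=O)oc3ccccc23)nn1`) gives 40% 
compound 3 (`COc1cc(/C=C/C(=O)/C=C/c2ccccc2)ccc1OCc1cn(CCCCOc2cc(=O)oc3ccccc23)nn1`) gives 31% 

The numbers above come from a functional assay on COLO 205 cells (Homo sapiens) for inhibition, read by sulforhodamine B assay, with a stated time of 48 h, tested at 50 uM (a higher number here means more inhibition of growth at the concentration tested, a lower number less inhibition of growth), and set the starting point. Compound 3 and compound 2 lie within the usual scatter of each other, so the data do not separate them. Compound 1 stands apart, and the data show a number 22 percentage points lower from compound 1 to compound 3 (beyond the scatter) in this series.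

Compound 4 (`COc1cc(/C=C/C(=O)/C=C/c2ccco2)ccc1OCc1cn(CCCCOc2cc(=O)oc3ccccc23)nn1`) has not yet been measured. Its change is furan-2-yl in place of phenyl on a double-bonded chain carbon bound to a double-bonded chain carbon and the rest of the structure stays the same. Going by the values given here, only one measured step falls at this place, namely a number 22 percentage points lower from compound 1 to compound 3 (beyond the scatter) for the exchange of 3,4-dimethoxyphenyl for phenyl. That step shows that the group here can move the number by a modest amount. It is a different exchange, however, and it says little about furan-2-yl. Compound 2 differs from compound 3 in more than one place, so it offers only its value. Among the compounds with values here, no measured compound carries furan-2-yl, so a small step with no firm direction is expected, most likely within the scatter.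

The expected step is a number 3 percentage points higher from compound 3 to compound 4 (within the scatter) and that is only an estimate. The estimated value for compound 4 is 34% with an expected range from 20% to 50% in this assay.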

Compound 4, percent growth inhibition at one concentration: 43%
For compound 4 the middle estimate is 9 percentage points below the measured one, within the range that was stated.
By their numbers in this assay, from the lowest: compounds 3, 2, 4 and 1 (each within the scatter of the next, the first and the last beyond it).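

In this assay, the exchange on a double-bonded chain carbon bound to a double-bonded chain carbon gives a number 12 percentage points higher from compound 3 to compound 4 (beyond the scatter), so this place is now shown to respond to a change of ring type, from a six-membered aromatic ring of carbon only to a five-membered aromatic ring with one hetero atom, and not only to the addition of substituents to phenyl. The comparison with the dimethoxy-substituted compound gives a number 10 percentage points lower from compound 1 to compound 4 (within the scatter), so the data do not separate furan-2-yl from 3,4-dimethoxyphenyl, while phenyl falls beyond the scatter of both, and a group at this place need not carry the methoxy groups of compound 1 to rise above phenyl. Nothing shown here gives a measured reason for the higher number with furan-2-yl.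

On these data alone, whether the ring oxygen or the smaller ring goes with this higher number remains open, and a thiophen-2-yl or a pyridin-2-yl group at this place would be needed to tell the two apart. It is also open whether furan-2-yl would keep its place against phenyl with a longer chain on the triazole nitrogen, as the only compound shown with a longer chain also carries a different ring.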